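The source may report more compounds than this note shows. Statements on the series, on what has been measured and on what is new or still open speak of the compounds shown alone.

Measured compounds in a functional assay on HL-60 cells (Homo sapiens) for cytotoxicity, read by WST assay, with a stated time of 48 h; a lower number here means that less compound is needed, a higher number that more compound is needed for the effect:

Compound 1, `O=C1OC[C@H](Cc2ccccc2)[C@H]1Cc1ccc(Cl)c(Cl)c1`, gives 19000 nM.
Compound 2, `Clc1ccc(C[C@H]2COC[C@@H]2Cc2ccccc2)cc1Cl`, gives 19000 nM.
Compound 3, `O=C1OC[C@H](Cc2cccc(O)c2)[C@H]1Cc1ccc(Cl)c(Cl)c1`, gives 48000 nM.

Compound 1 and compound 3 share a core and differ by one change, (hydroxy in place of hydrogen on an aromatic carbon). That change produced a 2.5-fold higher number from compound 1 to compound 3 (0.40 log units; beyond the scatter). Compound 2 stands level with compound 1 at the digits given, and its values sit within the scatter of each other; the difference between the two cores of compound 1 and compound 2 is not broken down here.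

Compound 4, `Oc1ccccc1C[C@H]1COC[C@@H]1Cc1ccc(Cl)c(Cl)c1`, has not yet been measured in this assay. It arises from compound 2 by hydroxy in place of hydrogen on an aromatic carbon. Going by the values given here, this is the same kind of change as the one from compound 1 to compound 3, but not the same: in compound 3 the hydroxy sits meta to a large group, whereas in compound 4 it sits ortho to a large group, and the core of compound 2 is a different one from that of compound 1.

Because compound 3 showed a 2.5-fold higher number from compound 1 to compound 3 (0.40 log units; beyond the scatter), a step of similar size, a 2.1-fold higher number from compound 2 to compound 4 (0.32 log units; beyond the scatter), is expected from compound 2 to compound 4. Among the compounds with values here, with only one earlier example, and that on another core and at another place on the ring, the expectation is loose. Compound 4 is thus estimated at 40000 nM, between 15000 nM and 110000 nM.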

Compound 4, half-maximal effective concentration: 34000 nM
The estimate for compound 4 lay 1.2-fold (0.07 log units) above the measured number; low and high end bracket the measured number.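

In this assay, hydroxy in place of hydrogen on an aromatic carbon gave a 1.8-fold higher number from compound 2 to compound 4 (0.25 log units; within the scatter), so on the core of compound 2 the step does not stand clear of the usual spread of repeated measurements. Set beside the step on the core of compound 1, the result gives no sign that the size of the step depends on the core: the same change on two cores in this assay, a 2.5-fold higher number (0.40 log units; beyond the scatter) from compound 1 to compound 3 and a 1.8-fold higher number (0.25 log units; within the scatter) from compound 2 to compound 4, 1.4-fold (0.15 log units) apart, within the scatter of two such steps This is thin support for carrying the change across, however: it rests on one pair per core, the hydroxy in compound 4 sits ortho to a large group and so not where it sits in compound 3, and the two steps agree only as far as the scatter allows, which shows neither that the core is without influence nor that the place on the ring is without influence.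

The compounds shown leave open whether the hydroxy, set at one and the same place on both cores, would give matching steps. They also leave open how a methoxy group, a fluorine atom or an amine in that place would read in this assay, on either core.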